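The source may report more compounds than this note shows. Statements on the series, on what has been measured and on what is new or still open speak of the compounds shown alone.

Measured so far:
- compound 1, `COc1ccc(CSc2cc(C(F)(F)F)ccc2CNC(=O)C(C)c2ccc(NS(C)(=O)=O)c(F)c2)cc1`: 2.3 nM
- compound 2, `CC(C(=O)NCc1ccc(C(F)(F)F)cc1F)c1ccc(NS(C)(=O)=O)c(F)c1`: 68.7 nM

In an assay on CHO cells for antagonist activity at transient receptor potential cation channel subfamily V member 1 (Homo sapiens), read by FLIPR (a higher number here means a weaker inhibitor, a lower number a stronger inhibitor), compound 2 stands at the higher of the two numbers; its nearest neighbour is compound 1, and the step of a 30-fold higher number from compound 1 to compound 2 (1.48 log units; beyond the scatter) separates them. Compound 2 thus holds the weaker position within this small set.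

Compound 3, `CC(C(=O)NCc1ccc(C(F)(F)F)cc1-c1cccc(F)c1)c1ccc(NS(C)(=O)=O)c(F)c1`, differs from compound 2 in one place: 3-fluorophenyl in place of fluoro on an aromatic carbon.

Among the measured compounds shown here, only one measured step bears on this position. It is a 30-fold higher number from compound 1 to compound 2 (1.48 log units; beyond the scatter), which shows that a large group at the place now occupied by fluoro goes with a much lower number in this assay. Compound 3 restores bulk there, though with a 3-fluorophenyl rather than the (4-methoxybenzyl)sulfanyl of compound 1, so the gain cannot simply be read across. The expectation is a lower number for compound 3 than for compound 2, of moderate size, but smaller than the measured step in the other direction. The expected step is a 4.6-fold lower number from compound 2 to compound 3 (0.66 log units; beyond the scatter), well beyond the scatter.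

Estimated for compound 3 in this assay: 15 nM, with a range of 4 nM to 60 nM.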

Compound 3, inhibition constant: 1.9 nM
Compound 3: middle estimate off by 7.9-fold (0.90 log units), on the high side, and the stated range ends above it.
By their numbers in this assay, from the lowest: compounds 3 and 1 (each within the scatter of the next); then compound 2.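

In this assay the position tolerates more than one large group: with a 36-fold lower number from compound 2 to compound 3 (1.56 log units; beyond the scatter) as the step, the low number no longer belongs to the (4-methoxybenzyl)sulfanyl group alone. With a 1.2-fold lower number from compound 1 to compound 3 (0.08 log units; within the scatter) as the comparison, 3-fluorophenyl and (4-methoxybenzyl)sulfanyl stand level on this aromatic carbon, so among these three compounds neither a sulfur atom nor the methoxy group is needed for the low number. No measurement available here explains why either group does so much better than fluoro.

Still open, as far as these compounds go, is what in 3-fluorophenyl carries the gain, since these compounds cannot separate the aromatic ring from its fluorine, and plain phenyl or a saturated cyclohexyl ring on the same carbon would test that directly. Also open, from the compounds shown here alone, is how far the position accepts other kinds of group, such as a piperidine amine, a carboxylic acid or a longer alkyl chain, and whether the fluorine of 3-fluorophenyl can sit elsewhere on its ring.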